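This account rests on a few compounds, and the source may have more. Where it says the series, first, only, none or still open, it means among the compounds named here.

Three compounds that share one core were measured in a functional assay on cardiac atrium for agonist activity at histamine H2 receptor (Cavia porcellus); a higher number here means a larger maximal response, a lower number a smaller maximal response. Compound 1 `N=C(NCCCc1c[nH]cn1)NCCSC(c1ccccc1)c1ccccn1` gives 1 in this assay. Compound 2 `N=C(NCCCc1c[nH]cn1)NCCCC(c1ccccc1)c1ccccn1` gives 1. Compound 3 `N=C(NCCCc1c[nH]cn1)NCCC(c1ccccc1)c1ccccn1` gives 1, so compound 3 stands level with compound 1 and compound 2 at the digits shown; the nearest of the two is compound 1, with no change within the scatter, and the furthest is compound 2, again with no change within the scatter. Each of the three reaches the full response of the reference agonist.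

Compound 4 `N=C(NCCCc1c[nH]cn1)NCCC(c1ccccn1)c1ccccc1F` has not been measured. It differs from compound 3 in one place: fluoro in place of hydrogen on an aromatic carbon. For the measured compounds named here, compounds 1, 2 and 3 differ among themselves elsewhere in the molecule and still all give the full response, so no step among the measured compounds points one way or the other, and no step between measured compounds is recorded for this single change. The step expected in this assay is no change at the digits printed from compound 3 to compound 4 (within the scatter), none beyond the usual scatter. Compound 4 is estimated to give 1, with a range from 0.9 to 1.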

Compound 4, intrinsic activity: the largest response reached, as a fraction of the reference agonist's: 1
Compound 4: the middle estimate sits on the measured number at the digits printed; the measured number falls inside the stated range.
By their numbers in this assay, from the lowest: compounds 1, 2, 3 and 4 (each within the scatter of the next).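

In this assay, for the compounds shown here, fluoro in place of hydrogen on an aromatic carbon, ortho to a large group, gives no change at the digits printed from compound 3 to compound 4 (within the scatter) and is the first single change in this set whose step can be read. It shows that going from phenyl to 2-fluorophenyl at this position leaves the compound at the full response of the reference agonist. Nothing available explains this outcome.

From the compounds shown here alone, whether chloro, methoxy, an amine or a carboxylic acid in the same place would also leave the maximal response unchanged remains open. The read-out gives only the largest response reached, so it also leaves open how much of each compound is needed to reach that response.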